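A Chloro Added to an Already Inactive Core

This account rests on a few compounds, and the source may have more. Where it says the series, first, only, none or still open, it means among the compounds named here.

Measured compounds:
- compound 1, `ClCc1ccccc1Cn1cnc2ncnc(Cl)c21`, > 100000 nM
- compound 2, `Nc1nc(Cl)c2ncn(Cc3cccc(CCl)c3)c2n1`, 67600 nM

Both compounds were tested in a functional assay on SF-268 cells (Homo sapiens) for cytotoxicity, read by sulforhodamine B assay, with a stated time of 48 h; on this read-out higher numbers stand for lower toxicity in this test and lower numbers for higher toxicity in this test. For compound 1 the read-out is a limit of the assay, not a number: it is reported as > 100000 nM. Compound 2, which carries a different substitution pattern on the shared core and an amino group, gives 67600 nM in this assay. For the measured compounds named here, with only these two points, and no pair of compounds differing in a single place, no measured step can be drawn; what is known about compound 1 is that it sits at the limit of > 100000 nM in this assay, at which 1 of the 2 values shown sits.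

The unmeasured compound 3, `ClCc1ccccc1Cn1cnc2nc(Cl)nc(Cl)c21`, is reached from compound 1 by a single change: chloro in place of hydrogen on an aromatic carbon. Going by the values given here, with compound 1 already at the limit and no comparable step on record, the step of a number no higher from compound 1 to compound 3 (the limit leaves the size open) from compound 1 to compound 3 is expected to be none beyond the usual scatter. Compound 3 is therefore estimated to give about 100000 nM in this assay, within a range from 30000 nM to 300000 nM.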

Compound 3, concentration lethal to 50% of the cells: > 100000 nM
Compound 3 ended at the assay's limit (the forecaster's own chance of this, stated with the estimate: 50%); the middle value sits exactly at the limit.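

In this assay compound 3 gives > 100000 nM, which is a limit of the assay and not a number. For the compounds shown here, compound 1 gives > 100000 nM, also a limit, so no step between compound 1 and compound 3 can be read. The compounds shown leave open whether chloro in place of hydrogen on an aromatic carbon changes the toxicity of this core at all.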